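Swapping the ring at one chain end: a plasma stability question

The source may hold more compounds than are shown below. What is called first, only, known or untested is meant among the compounds shown, and "the series" means these compounds.

Three compounds sharing a long flexible linker between two aromatic ends have been tested in an ADME assay on a cell-free system (plasma, Rattus norvegicus) for metabolic stability, read by LC-MS, with a stated time of 60 min, tested at 100 uM; a higher number here means that more of the compound is left, a lower number that less of the compound is left. Compound 1, with the structure `COc1cc(C(=O)O)ccc1OCCCCOc1ccc(C(=O)CC(C)C)c(O)c1C`, gives 99%. Compound 3, with the structure `Cc1c(OCCCCOc2ccc(C(=O)CC(C)(C)C)c(O)c2C)cccc1C(=O)O`, gives 89%. Compound 2, with the structure `Cc1c(OCCCCOc2ccc(C(=O)O)cc2Cl)ccc(C(=O)CC2CCCC2)c1O`, gives 120%, the highest of the three numbers: it lies above compound 1 by a gap beyond the scatter and further above compound 3, also beyond the scatter.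

Compound 4, with the structure `Cc1ccc(C(=O)O)cc1OCCCCOc1ccc(C(=O)CC2CCCC2)c(O)c1C`, has not yet been measured in this assay. It differs from compound 2 at one place: 5-carboxy-2-methylphenyl in place of 4-carboxy-2-chlorophenyl on an oxygen on a saturated carbon. Compound 1 and compound 3, which both carry a methyl-bearing ring rather than a chlorine-bearing one at that end, sit somewhat lower than compound 2, so a modest downward step is expected, estimated as a number 20 percentage points lower from compound 2 to compound 4 (beyond the scatter), likely just beyond the scatter. Compound 4 is therefore expected to give about 100%, within a range from 85% to 115%.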

Compound 4, percent of the compound remaining: 100%
Beside the measured number, compound 4's estimate shows no gap at the digits printed; the range from low to high includes it.
By their numbers in this assay, from the lowest: compounds 3, 1 and 4 (each within the scatter of the next, the first and the last beyond it); then compound 2.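

In this assay, putting 5-carboxy-2-methylphenyl in place of 4-carboxy-2-chlorophenyl on an oxygen on a saturated carbon gives a number 20 percentage points lower from compound 2 to compound 4 (beyond the scatter). Among these compounds, this is the first pair here that differs in one place only, so the step belongs to this end of the chain, but the swap changes two things at once: a methyl stands where the chlorine was named, and the carboxy group carries a different ring number. No measurement shown gives a reason for the step.

The compounds shown leave open which of those two differences carries the step, a question that 4-carboxy-2-methylphenyl at the same place would address. They also leave open how a ring bearing a fluorine or an amine at this chain end would read in this assay.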